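The source may hold more compounds than are shown below. What is called first, only, known or untested is meant among the compounds shown, and "the series" means these compounds.

Measured so far:
Compound 1, `FC(F)(F)c1cccc(-c2nc3cnc(Nc4ccccn4)cc3[nH]2)c1`, gives 45% in an ADME assay on microsomes from liver (Rattus norvegicus) for metabolic stability, read by LC-MS, with a stated time of 30 min, tested at 0.1 uM; on this read-out higher numbers stand for a more stable compound and lower numbers for a less stable compound.
Compound 2, `FC(F)(F)c1cccc(-c2nc3cnc(Nc4ccncn4)cc3[nH]2)c1`, gives 88% in this assay.
Compound 3, `Fc1ccc(-c2nc3cnc(Nc4ccccn4)cc3[nH]2)cc1F`, gives 48% in this assay.

Compound 2 stands highest of these three numbers, beyond the scatter against both others: compound 3 sits nearest below it, compound 1 furthest below. The next compound, compound 4, `N#Cc1ccc(Nc2cc3[nH]c(-c4cccc(C(F)(F)F)c4)nc3cn2)nc1`, has not yet been measured. It differs from compound 2 in a single place: 5-cyanopyridin-2-yl in place of pyrimidin-4-yl on a nitrogen on an aromatic ring. Going by the values given here, one measured step bears on this change. Going from compound 1 to compound 2 exchanges a pyridin-2-yl for the pyrimidin-4-yl, and that step reads a number 43 percentage points higher from compound 1 to compound 2 (beyond the scatter). Compound 4 goes the other way, back to a ring with one hetero atom, now a pyridin-2-yl carrying a nitrile. Compound 3, which also carries a plain pyridin-2-yl on the same nitrogen, lies close to compound 1. The nitrile itself has no measured counterpart among these compounds, so its contribution is unknown. The expectation is therefore a drop from compound 2, a number 28 percentage points lower from compound 2 to compound 4 (beyond the scatter), though taken as smaller than a full reversal of the measured step. Compound 4 is expected to give 60% in this assay, within a range of 35% to 85%.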

Compound 4, percent of the compound remaining: 49%
Compound 4: the middle estimate sits 11 percentage points above what was measured; low and high end bracket the measured number.
By their numbers in this assay, from the lowest: compounds 1, 3 and 4 (each within the scatter of the next); then compound 2.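

Swapping pyrimidin-4-yl for 5-cyanopyridin-2-yl on this nitrogen gives, in this assay, a number 39 percentage points lower from compound 2 to compound 4 (beyond the scatter), so the high number of compound 2 does not carry over to a ring with 1 hetero atom, even one bearing a nitrile. Adding cyano in place of hydrogen on an aromatic carbon of the pyridin-2-yl ring reads a number 4 percentage points higher from compound 1 to compound 4 (within the scatter), so the nitrile does not set these two compounds apart in this assay. Among compounds 1, 2 and 4, which differ only in the group on this nitrogen, compound 2 with its pyrimidin-4-yl is thus the only one that stands apart, and a nitrile on the pyridin-2-yl ring does not reach it.

Nothing shown here explains why these rings give such different numbers. Going by these compounds, it also remains open whether a pyrimidin-4-yl ring would hold the number of compound 2 when it carries a further group, such as a nitrile, a methoxy group or an amine.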